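The compounds below may be only part of what the source reports. "The series", "measured", "known", "first", "only" and "open" are said of these compounds alone.

Of the compounds shown here, three from this series have been tested in an assay for inhibition of 15-hydroxyprostaglandin dehydrogenase [NAD(+)] (Homo sapiens), read by fluorescence and spectrophotometry; a lower number here means a stronger inhibitor, a higher number a weaker inhibitor. Compound 1, `CC(C)OCCOc1ccc(/C=C2\SC(=O)NC2=O)c(Cl)c1`, gives 1050 nM in this assay. Compound 3, `O=C1NC(=O)/C(=C/c2ccc(OCc3ccc([N+](=O)[O-])cc3)cc2Cl)S1`, gives 4540 nM, and compound 2, `O=C1N=C(O)S/C1=C\c1ccc(OCCc2ccccn2)cc1Cl`, gives 8920 nM. Compound 1 therefore stands as the lowest of the three numbers, so in this assay it is the strongest inhibitor of the group: compound 3 lies beyond the usual scatter of repeated measurements from it, and compound 2 lies further still.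

Compound 4, `O=C1NC(=O)/C(=C/c2ccc(OCCOC3CCCCC3)cc2Cl)S1`, has not yet been measured in this assay. It keeps the shared core of compound 1 and changes one thing: cyclohexyl in place of isopropyl on an oxygen on a saturated carbon. Among the compounds with values here, no pair of measured compounds differing in only one place is available here, so there is no directly comparable step to lean on. The change is a swap of one saturated carbon group for a larger one at the same oxygen, and the other three compounds all carry different tails at that position, each weaker than compound 1.

The expectation for the step of a 1.3-fold lower number from compound 1 to compound 4 (0.12 log units; within the scatter) is a small change, if any, in this assay, and most likely one that stays within the scatter. Compound 4 is estimated to give about 800 nM in this assay, with a plausible range from 250 nM to 2600 nM.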

Compound 4, half-maximal inhibitory concentration: 211 nM
Estimate against measurement, compound 4: 3.8-fold (0.58 log units) above; the whole stated range lies above it.
By their numbers in this assay, from the lowest: compound 4; then compound 1; then compounds 3 and 2 (each within the scatter of the next).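

This is the only pair shown that differs in a single place, so the change can be read on its own: in this assay, cyclohexyl in place of isopropyl on an oxygen on a saturated carbon gives a 5.0-fold lower number from compound 1 to compound 4 (0.70 log units; beyond the scatter) and moves the series to a lower number. The group on this oxygen therefore affects inhibition, and here the larger group, with its six-membered non-aromatic ring of carbon only, gives the stronger inhibitor. The data shown give no explanation for why the number falls.

Within the data shown here, with only this one step, it remains open whether the ring itself matters or whether the larger number of carbons alone is enough, and a straight hexyl chain or a cyclopentyl group on the same oxygen would help separate those two readings. On these data alone, it is also open how far this trend extends, for example to a phenyl group, a larger cycloheptyl ring, or a cyclohexyl ring carrying an amine or a carboxylic acid.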